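Trading a methoxycarbonyl for a 4-methoxyphenyl on the core

The source may report more compounds than this note shows. Statements on the series, on what has been measured and on what is new or still open speak of the compounds shown alone.

Compound 1 `COC(=O)c1cc(=O)c2c(OC)cc(OC)cc2n1S(=O)(=O)c1ccc(C)cc1` is the reference point of this small set. Going by the values given here, in a functional assay on KOPN-8 cells (Homo sapiens) for antiproliferative activity, with a stated time of 72 h (a lower number here means that less compound is needed, a higher number that more compound is needed for the effect), compound 1 gives 6000 nM, the only numerical reading among the three measured compounds. Compound 2 `COC(=O)c1cc(=O)c2cc(N)ccc2[nH]1` gives in this assay only > 33700 nM, which is a limit of the assay and not a number. Compound 3 `COc1ccc(-c2cc(=O)c3c(OC)cc(OC)cc3n2S(=O)(=O)c2ccc(C)c([N+](=O)[O-])c2)cc1` likewise gives in this assay only > 51700 nM, again a limit rather than a number. Two of the three values thus sit at a limit: the limit of > 33700 nM in this assay, at which 1 of the 3 values shown sits, and (the limit of > 51700 nM in this assay, at which 1 of the 3 values shown sits). Among the compounds with values here, no step between measured compounds that differ in a single place is available, so no measured step guides the comparison. Compound 4 `COc1ccc(-c2cc(=O)c3c(OC)cc(OC)cc3n2S(=O)(=O)c2ccc(C)cc2)cc1` has not yet been measured. It differs from compound 1 in one place: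

4-methoxyphenyl in place of methoxycarbonyl on an aromatic carbon

The step of a 3.3-fold higher number from compound 1 to compound 4 (0.52 log units; beyond the scatter) is expected to reach beyond the usual scatter, in the direction of more compound being needed. In this assay compound 4 is estimated at 20000 nM, with a range from 5000 nM to 60000 nM, and a limit rather than a number may well be what the assay reports.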

Compound 4, half-maximal effective concentration: > 44800 nM
Compound 4: only a limit was reported; the forecaster's own chance of this, stated with the estimate: 40%; middle value at least 2.2-fold (0.35 log units) from the limit.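

Going by these compounds alone, at this position, on an aromatic carbon next to the ring nitrogen, 4-methoxyphenyl in place of methoxycarbonyl gives an at least 7.4-fold higher number from compound 1 to compound 4 (0.87 log units; beyond the scatter) in this assay, the first readable step in this set, and it runs toward more compound being needed. On these data alone, compound 4 gives only a limit and not a number, so the full size of this step stays unknown: the limit of > 44800 nM in this assay, at which 1 of the 4 values shown sits. The step from compound 3 to compound 4, hydrogen in place of nitro, cannot be read: both values are limits.

The compounds shown leave open whether a carboxylic acid or a primary amide at this position would keep a reading near that of compound 1. They also leave open whether an unsubstituted phenyl would behave like 4-methoxyphenyl, and what in this change accounts for the higher number.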